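A few compounds are considered here, and "the series" means these few. Any claim that something is new, unique, unknown or untested is made for them only; others in the source may bear on it.

Measured compounds in an assay on HEK293 cells for inhibition of Lysophosphatidylserine lipase ABHD12 (Homo sapiens), read by scintillation counting, with stated times of 30 min and 5 min; a higher number here means a weaker inhibitor, a lower number a stronger inhibitor:
compound 1, `Cc1ccc(C(=O)NC2CCCCCC2)c(=O)n1Cc1ccc(F)cc1`, a limit of > 10000 nM
compound 2, `Cc1c(Br)cc(C(=O)NC2CCCCCC2)c(=O)n1Cc1ccc(F)cc1`, a limit of > 10000 nM
compound 3, `Cc1nc(OCc2ccc(F)cc2)c(C(=O)NC2CCCCCC2)cc1-c1ccc(F)cc1`, a limit of > 10000 nM

Compound 1 gives in this assay only the limit > 10000 nM and no number. Compound 2 likewise stops at the limit > 10000 nM. The step from compound 1 to compound 2 is therefore a step that the two limits leave unreadable from compound 1 to compound 2. Compound 3 also returns only the limit > 10000 nM, not a number. All three values sit at the limit of > 10000 nM in this assay, at which 3 of the 3 values shown sit, so compound 3 cannot be placed against the other two beyond sharing that limit with them, and no order among the three can be read.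

Compound 4, `Cc1ccc(C(=O)NC2CCCCCC2)c(OCc2ccc(F)cc2)n1`, differs from compound 3 by hydrogen in place of 4-fluorophenyl on an aromatic carbon. For the measured compounds named here, no measured step concerns removal of an aryl group from the shared core, and the single step available, a step that the two limits leave unreadable from compound 1 to compound 2, is itself not readable. No direction and no size can be drawn from the series for this change. The step from compound 3 to compound 4 is accordingly estimated as a step that the limit leaves unreadable from compound 3 to compound 4, which is no more than the shared limit permits. Compound 4 is expected to give 20000 nM, within a range of 5000 nM to 100000 nM, and most probably to be reported again only as a limit.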

Compound 4, half-maximal inhibitory concentration: > 10000 nM
Compound 4: no number, only a limit (the forecaster's own chance of this, stated with the estimate: 85%); the middle value does not contradict the limit.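

In this assay compound 4 gives > 10000 nM, a limit and not a number. Compound 3 also stops at a limit, so the step between compound 3 and compound 4 cannot be read. The compounds shown leave open whether any change to the shared core gives a measurable value: the limit of > 10000 nM in this assay, at which 4 of the 4 values shown sit.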